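The compounds below may be only part of what the source reports. "The series", "measured", "known", "first", "only" and "open" are said of these compounds alone.

Measured compounds:
compound 1 `C=C1CN(C)N(c2ccc(Cl)cc2)C1=O`: 38100 nM
compound 2 `C=C1CN(C)N(c2ccccc2)C1=O`: 45700 nM
compound 3 `C=C1CN(C)N(c2ccc(Br)cc2)C1=O`: 51800 nM

In a functional assay on HL-60 cells (Homo sapiens) for inhibition, read by MTT assay, with a stated time of 48 h (on this read-out higher numbers stand for weaker inhibition and lower numbers for stronger inhibition), the three numbers sit close together. From compound 1 to compound 2 the change is a 1.2-fold higher number from compound 1 to compound 2 (0.08 log units; within the scatter), from compound 1 to compound 3 it is a 1.4-fold higher number from compound 1 to compound 3 (0.13 log units; within the scatter), and from compound 2 to compound 3 it is a 1.1-fold higher number from compound 2 to compound 3 (0.05 log units; within the scatter); none of these separates from the others, so compound 2 is neither set apart from compound 1 nor from compound 3.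

Compound 4 `C=C1C(=O)N(c2ccccc2)N(C)C1CC` is not yet measured. It differs from compound 2 by ethyl in place of hydrogen on a saturated ring carbon. Among the compounds with values here, all measured steps concern a substituent on the aromatic ring; no measured step touches the saturated ring carbon of the shared core, so nothing here speaks to the size or direction of this change. With that gap, the working expectation is a step of a 1.1-fold higher number from compound 2 to compound 4 (0.04 log units; within the scatter), which is no more than the scatter of the three measured values. Compound 4 is therefore estimated at 50000 nM in this assay, with a range from 18000 nM to 150000 nM.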

Compound 4, half-maximal inhibitory concentration: 750000 nM
Beside the measured number, compound 4's estimate is 15-fold (1.18 log units) below it; measured number outside the range, above it.
By their numbers in this assay, from the lowest: compounds 1, 2 and 3 (each within the scatter of the next); then compound 4.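

In this assay the saturated ring carbon next to the ring nitrogen responds strongly to substitution: ethyl in place of hydrogen gives a 16-fold higher number from compound 2 to compound 4 (1.22 log units; beyond the scatter) and so moves the number well beyond the scatter. The earlier steps shown here showed no such response, since hydrogen, chloro and bromo on the aromatic ring all stayed within the scatter of one another. The series therefore holds one change that clearly weakens inhibition, and the data at hand offer no explanation for it.

On these data alone, it remains open whether a methyl, a longer chain such as propyl, or an amine on this saturated ring carbon would give a step of similar magnitude. As far as these compounds go, it is also open whether ethyl here would have the same effect with chloro or bromo on the aromatic ring.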